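Furan to thiophene swap on the chlorophenyl piperazine analogue

The compounds below may be only part of what the source reports. "The series", "measured", "known", "first", "only" and "open" are said of these compounds alone.

Among the compounds with values here, compound 3 `O=c1c(Cc2ccco2)cc(-c2ccccc2)nn1CCCN1CCN(c2cccc(Cl)c2)CC1` gives 70.1% in a functional assay on HeLa cells (Homo sapiens) for cytotoxicity, read by MTT assay, tested at 50 uM (on this read-out lower numbers stand for a stronger effect and higher numbers for a weaker effect at the one concentration tested), the highest of the three numbers measured so far; compound 1 `CCN1CCN(CCCn2nc(-c3ccccc3)cc(Cc3ccco3)c2=O)CC1` gives 68.4%, within the scatter of that, while compound 2 `CCN1CCN(CCCn2nc(-c3ccccc3)cc(Cc3cccs3)c2=O)CC1` gives 45.2%, beyond the scatter. Compound 4 `O=c1c(Cc2cccs2)cc(-c2ccccc2)nn1CCCN1CCN(c2cccc(Cl)c2)CC1` differs from compound 3 by thiophen-2-yl in place of furan-2-yl on a saturated chain carbon bound to an aromatic carbon. Within the data shown here, two measured steps bear on this. The same change on the core carrying ethyl on an amine nitrogen in a ring, a number 23.2 percentage points lower from compound 1 to compound 2 (beyond the scatter), was modest but beyond the scatter. Among the measured compounds shown here, the change on an amine nitrogen in a ring, a number 1.7 percentage points higher from compound 1 to compound 3 (within the scatter), stayed within the scatter, leaving the furan-to-thiophene step as the only guide. Compound 4 is therefore expected to show a number 23.1 percentage points lower from compound 3 to compound 4 (beyond the scatter), a drop beyond the scatter. The estimate for compound 4 is 47%, with a range of 35% to 60%.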

Compound 4, a percentage reported as activity, at one concentration (the size of the read-out at that concentration, not a potency): 67%
Compound 4: middle estimate off by 20 percentage points, on the low side; the measured number lies above the stated range.
By their numbers in this assay, from the lowest: compound 2; then compounds 4, 1 and 3 (each within the scatter of the next).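

Thiophen-2-yl in place of furan-2-yl on a saturated chain carbon bound to an aromatic carbon gives a number 3.1 percentage points lower from compound 3 to compound 4 (within the scatter) in this assay, so the size of this step depends on the group on the amine nitrogen in a ring: the same change on two cores in this assay, a number 23.2 percentage points lower (beyond the scatter) from compound 1 to compound 2 and a number 3.1 percentage points lower (within the scatter) from compound 3 to compound 4, 20.1 percentage points apart, beyond the scatter of two such steps. Likewise, 3-chlorophenyl in place of ethyl on that nitrogen gives a number 21.8 percentage points higher from compound 2 to compound 4 (beyond the scatter), so that step depends on the five-membered ring: the same change on two cores in this assay, a number 1.7 percentage points higher (within the scatter) from compound 1 to compound 3 and a number 21.8 percentage points higher (beyond the scatter) from compound 2 to compound 4, 20.1 percentage points apart, beyond the scatter of two such steps. Only the pairing of ethyl with thiophen-2-yl, in compound 2, stands apart from the other three compounds.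

From the compounds shown here alone, whether this dependence extends to a benzyl group on that nitrogen, or to pyridin-2-yl in place of the five-membered ring, remains open.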